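Pyridine in Place of Pyrimidine on a Weak Series

The source may report more compounds than this note shows. Statements on the series, on what has been measured and on what is new or still open speak of the compounds shown alone.

Of the compounds shown here, three have been measured in an assay for inhibition of steroid 17-alpha-hydroxylase/17,20 lyase (Homo sapiens), using NADPH, tested at 0.2 uM (on this read-out lower numbers stand for a weaker effect and higher numbers for a stronger effect at the one concentration tested), and all sit near the bottom of the scale. Compound 1 `COc1ccc(-c2csc(Cn3ccnc3)c2)cc1` gives 0% there, compound 3 `Fc1ccc(-c2ccc(Cn3ccnc3)nc2)cc1` gives 0% there, and compound 2 `c1cn(Cc2ccc(-c3cncnc3)cc2)cn1` gives 5% there. Among the measured compounds shown here, compound 2 holds the highest of the three numbers, yet its gaps to compound 1 and to compound 3 both lie within the usual scatter, so no compound can be set apart from the rest. Compound 4 `c1cncc(-c2ccc(Cn3ccnc3)cc2)c1` is not yet measured and differs from compound 2 in one place: pyridin-3-yl in place of pyrimidin-5-yl on an aromatic carbon in words as stated. For the measured compounds named here, no step between measured compounds guides this change, so the step expected in this assay is no change at the digits printed from compound 2 to compound 4 (within the scatter) and none beyond the scatter. Compound 4 is estimated at 5% with a range from 0% to 15% in that assay.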

Compound 4, a percentage reported as inhibition, at one concentration (the size of the read-out at that concentration, not a potency): 2%
Beside the measured number, compound 4's estimate is 3 percentage points above it, within the range that was stated.
By their numbers in this assay, from the lowest: compounds 1, 3, 4 and 2 (each within the scatter of the next).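

In this assay, among the compounds shown here, pyridin-3-yl in place of pyrimidin-5-yl gives a number 3 percentage points lower from compound 2 to compound 4 (within the scatter), the first step here that isolates a single place. On this aromatic carbon, para to the (1H-imidazol-1-yl)methyl group, the two rings therefore cannot be told apart, and both compounds stay near the bottom of the scale. Nothing measured here speaks to the reason. On these data alone, whether an amine or a carboxylic acid at this position would lift the read-out clear of the scatter remains open. So does whether these compounds would separate at a higher concentration.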